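Hydroxy for methoxy in a growth-inhibition series at the limit

The source may hold more compounds than are shown below. What is called first, only, known or untested is meant among the compounds shown, and "the series" means these compounds.

Three compounds of the shared core have been run in a functional assay on OVCAR-4 cells (Homo sapiens) for inhibition, read by sulforhodamine B assay, with a stated time of 48 h; on this read-out higher numbers stand for weaker inhibition of growth and lower numbers for stronger inhibition of growth. Compound 1 `COc1cc(C)cc(-c2c(-c3ccnc(-c4ccc(N(C)C)cc4)c3)cnn2CC#N)c1` gives > 100000 nM, which is a limit of the assay and not a number. Compound 2 `COc1cc(C)cc(-c2nn(CC#N)cc2-c2ccnc(-c3ccc(N(C)C)cc3)c2)c1` also gives > 100000 nM, again a limit rather than a measured number. Compound 3 `COc1cc(C)cc(-c2nn(CC#N)cc2-c2ccc(-c3cccc(C(C)=O)c3)nc2)c1` likewise returns > 100000 nM, a limit. Compound 2 therefore stands at the limit of > 100000 nM in this assay, at which 3 of the 3 values shown sit; no measured number sets it apart from compound 1 or compound 3, and none of the three can be called more or less active than another.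

The next compound, compound 4 `Cc1cc(O)cc(-c2nn(CC#N)cc2-c2ccnc(-c3ccc(N(C)C)cc3)c2)c1`, differs from compound 2 in one place: hydrogen in place of methyl on an oxygen on an aromatic ring. Within the data shown here, no step between measured compounds exists in this set, so nothing shows how a change of this kind has moved the read-out before.

With every known value resting at the limit and the change confined to the oxygen on the aromatic ring, the expectation is that compound 4 again sits at or near the limit in this assay. The expected step is a number no higher from compound 2 to compound 4 (the limit leaves the size open), none beyond the scatter. Compound 4 is estimated at 100000 nM, within 30000 nM to 300000 nM, with a high chance that only a limit is reported.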

Compound 4, concentration for total growth inhibition: > 100000 nM
Compound 4: no number, only a limit; the forecaster's own chance of this, stated with the estimate: 85%; the middle value sits exactly at the limit.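

Compound 2 and compound 4 both rest at a limit and not at a number, so no step can be read between them for methoxy to hydroxy: the limit of > 100000 nM in this assay, at which 4 of the 4 values shown sit.

The compounds shown leave open whether methoxy to hydroxy changes growth inhibition at all, and which change to the shared core would give a measured number.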